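The source may hold more compounds than are shown below. What is called first, only, known or untested is meant among the compounds shown, and "the series" means these compounds.

For the measured compounds named here, compound 1 `COc1cccc(-n2cc(COc3cccc(NC(=O)Nc4ccc(Cl)c(C(F)(F)F)c4)c3)nn2)c1` is the stronger of the two compounds measured so far in a functional assay on HepG2 cells (Homo sapiens) for inhibition, read by MTT assay, with a stated time of 72 h; a higher number here means a weaker inhibitor, a lower number a stronger inhibitor. In this assay compound 1 gives 1310 nM. Compound 2 `Cc1ccccc1-n1cc(COc2cccc(NC(=O)Nc3ccc(Cl)c(C(F)(F)F)c3)c2)nn1` shares the same core but carries a 2-methylphenyl group on the aromatic nitrogen; in this assay compound 2 gives 3440 nM. Going by the values given here, compound 1 therefore holds the lowest of the two numbers, and the single measured step, a 2.6-fold higher number from compound 1 to compound 2 (0.42 log units; beyond the scatter), shows a modest weakening when the 3-methoxyphenyl is exchanged.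

Compound 3 `CC(C)c1ccc(-n2cc(COc3cccc(NC(=O)Nc4ccc(Cl)c(C(F)(F)F)c4)c3)nn2)cc1` has not yet been measured. It differs from compound 1 as follows: 4-isopropylphenyl in place of 3-methoxyphenyl on an aromatic nitrogen. The step from compound 1 to compound 2 is the only one that bears on this change, since it alters the same group on the same aromatic nitrogen; it was a 2.6-fold higher number from compound 1 to compound 2 (0.42 log units; beyond the scatter). Both exchanges remove the one hydrogen-bond acceptor of the 3-methoxyphenyl, so a modest rise in the number is expected, though the entering group is not the same. For compound 3 the expected step is a 1.7-fold higher number from compound 1 to compound 3 (0.23 log units; within the scatter). Compound 3 is estimated at 2200 nM, within a range from 900 nM to 5500 nM.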

Compound 3, half-maximal inhibitory concentration: 2470 nM
Compound 3: the middle estimate sits 1.1-fold (0.05 log units) below what was measured; low and high end bracket the measured number.
By their numbers in this assay, from the lowest: compounds 1, 3 and 2 (each within the scatter of the next, the first and the last beyond it).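

In this assay, putting 4-isopropylphenyl in place of 3-methoxyphenyl on the aromatic nitrogen gives a 1.9-fold higher number from compound 1 to compound 3 (0.28 log units; within the scatter), so this larger all-carbon group, with no hydrogen-bond acceptor, cannot be told apart from the 3-methoxyphenyl group of compound 1. Putting 4-isopropylphenyl in place of 2-methylphenyl gives a 1.4-fold lower number from compound 2 to compound 3 (0.14 log units; within the scatter), so compound 3 also cannot be told apart from compound 2, although the earlier step of a 2.6-fold higher number from compound 1 to compound 2 (0.42 log units; beyond the scatter) lies beyond the scatter; the loss of the acceptor therefore does not by itself go with a clear change, since compound 3 lacks it and stays within the scatter of compound 1, while compound 2 lacks it and does not. No measurement offered here explains these numbers.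

The three groups differ both in what is attached to the phenyl ring and in where it is attached, so these two changes cannot be separated. On these data alone, it also remains open how this position would respond to an amine or a carboxylic acid on the phenyl ring, or to a longer chain in place of the ring.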